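The source may report more compounds than this note shows. Statements on the series, on what has been measured and on what is new or still open speak of the compounds shown alone.

Measured so far in a functional assay on cells for inhibition of Polyunsaturated fatty acid 5-lipoxygenase (Homo sapiens); on this read-out higher numbers stand for weaker inhibition and lower numbers for stronger inhibition:
compound 1 `O=C1NCCN(c2cccc(Cl)c2)N1`: 2100 nM
compound 2 `CC1CN(c2cccc(Cl)c2)NC(=O)N1`: 2700 nM
compound 3 `O=C1NCCN(c2cccc(Br)n2)N1`: 4600 nM

Compound 1 and compound 2 share one core and differ by methyl in place of hydrogen on a saturated ring carbon. On this read-out the step is a 1.3-fold higher number from compound 1 to compound 2 (0.11 log units; within the scatter), so the methyl leaves the number essentially where it was. Compound 3 stands on a second core; the difference between the two cores is not broken down here. Against compound 2 the number of compound 3 lies within the scatter; against compound 1 it is higher and lies beyond it.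

Compound 4 `CC1CN(c2cccc(Br)n2)NC(=O)N1` is not yet measured. It differs from compound 3 by methyl in place of hydrogen on a saturated ring carbon, the same change, at the same place, as from compound 1 to compound 2. Among the measured compounds shown here, only that one measured instance is available to judge it by. Because a 1.3-fold higher number from compound 1 to compound 2 (0.11 log units; within the scatter) lies within the scatter, the step to compound 4 is expected to be of similar small size, a 1.3-fold higher number from compound 3 to compound 4 (0.12 log units; within the scatter). Compound 4 is therefore estimated at 6000 nM, with a likely range of 3000 nM to 12000 nM in this assay.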

Compound 4, half-maximal inhibitory concentration: 3100 nM
Estimate against measurement, compound 4: 1.9-fold (0.29 log units) above; the measured number falls inside the stated range.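

In this assay, methyl in place of hydrogen on a saturated ring carbon gives a 1.5-fold lower number from compound 3 to compound 4 (0.17 log units; within the scatter), so on the core of compound 3 the change again leaves the number within the scatter. Set beside the earlier step, the result on this core does not differ from that on the core of compound 1, and the change carries across both cores as a step too small to read: the same change on two cores in this assay, a 1.3-fold higher number (0.11 log units; within the scatter) from compound 1 to compound 2 and a 1.5-fold lower number (0.17 log units; within the scatter) from compound 3 to compound 4, 1.9-fold (0.28 log units) apart, within the scatter of two such steps. Among the compounds shown here, this rests on only two pairs, so it shows that the methyl is tolerated on these two cores, but it gives the change no direction and says nothing about any further core.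

The compounds shown leave open whether a longer chain such as ethyl, or a hydroxymethyl group, on the same saturated ring carbon would move the number beyond the scatter. Also open, going by these compounds, is what an amine or a carboxylic acid in place of the chlorine or bromine would do.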